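Tolerated concentration across three ether variants of one core

A few compounds are considered here, and "the series" means these few. Any claim that something is new, unique, unknown or untested is made for them only; others in the source may bear on it.

Measured so far in an ADME assay on HEL cells (Homo sapiens) for cytotoxicity, with a stated time of 3 days; a higher number here means that more compound is tolerated, a lower number that less compound is tolerated:
compound 1 `CCC1(Cc2ccccc2)OS(=O)(=O)C=C1OCC(=O)OC` gives > 400000 nM.
compound 2 `CCC1(Cc2ccccc2)OS(=O)(=O)C=C1OCc1ccc(Cl)c(Cl)c1` gives >= 20000 nM.
compound 3 `CCC1(Cc2ccccc2)OS(=O)(=O)C=C1OCC=C(C)C` gives 400000 nM.

Compound 1 stands at a limit of this assay, not at a number, and the same holds for compound 2, whose value is also a limit. Only compound 3 has a true number. Of the steps between these three, a number no higher from compound 1 to compound 3 (the limit leaves the size open), while a step that the two limits leave unreadable from compound 1 to compound 2 and a step that the limit leaves unreadable from compound 2 to compound 3 give no readable size either.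

The next compound is compound 4 `CCC1(Cc2ccccc2)OS(=O)(=O)C=C1OCCc1ccccc1`. Relative to compound 1 the change is benzyl in place of methoxycarbonyl on a saturated chain carbon bound to an oxygen on an unsaturated carbon. Within the data shown here, the two steps that bear on it are those leaving compound 1, a step that the two limits leave unreadable from compound 1 to compound 2 and a number no higher from compound 1 to compound 3 (the limit leaves the size open); neither gives a size, so no step of a defined size is expected here beyond the scatter. Among the measured compounds shown here, of the two, the exchange most nearly resembles the one to compound 2, since both bring in an aromatic ring at the same place; the limit there (the limit of >= 20000 nM in this assay, at which 1 of the 3 values shown sits) leaves the outcome open.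

Compound 4 is therefore expected at 100000 nM, within 20000 nM to 400000 nM. This estimate means a step of an at least 4.0-fold lower number from compound 1 to compound 4 (0.60 log units; beyond the scatter), with a fair chance that only a limit is reported.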

Compound 4, minimum cytotoxic concentration: >= 20000 nM
Compound 4: only a limit was reported (the forecaster's own chance of this, stated with the estimate: 40%); the middle value does not contradict the limit.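

In this assay compound 4 gives >= 20000 nM, which is a limit. Among these compounds, no step to compound 4 from compound 1, compound 2 or compound 3 can be read. Left open is where compound 2 and compound 4 truly stand relative to compound 3, whose 400000 nM is the only true number.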